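A few compounds are considered here, and "the series" means these few. Any claim that something is new, unique, unknown or untested is made for them only; others in the source may bear on it.

Of the compounds shown here, three sharing one core have been measured in a physicochemical assay for solubility, with a stated time of 18 h, at pH 7.4; a higher number here means a more soluble compound, a lower number a less soluble compound. Compound 3 `c1ccc(-c2ccc3c(NCCCNCc4ccco4)ccnc3c2)cc1` gives 32000 nM in this assay, level with compound 2 `CC(C)(C)c1ccc(-c2ccc3c(NCCCNCc4ccco4)ccnc3c2)cc1`, which gives 32000 nM in this assay; together these two stand highest of the three. Compound 1 `c1ccc(CCc2ccc3c(NCCCNCc4ccco4)ccnc3c2)cc1` gives 4200 nM in this assay, the lowest number of the set. The step of a 7.6-fold higher number from compound 1 to compound 3 (0.88 log units; beyond the scatter) and the step of a 7.6-fold higher number from compound 1 to compound 2 (0.88 log units; beyond the scatter) were modest yet beyond the scatter, while the step of no change at the digits printed from compound 2 to compound 3 (within the scatter) stayed within it.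

Compound 4 `c1coc(CNCCCNc2ccnc3cc(-c4cccc5ccccc45)ccc23)c1` has not yet been measured in this assay. It differs from compound 3 in one place: naphthalen-1-yl in place of phenyl on an aromatic carbon. The closest guide among the measured steps is no change at the digits printed from compound 2 to compound 3 (within the scatter), where a group was removed from the phenyl ring and the number did not move. Among the compounds with values here, no measured step covers the addition of a whole second ring to that phenyl, so it is uncertain whether the number in this assay will shift beyond the scatter; the estimate therefore leans only slightly toward a lower number. Compound 4 is expected to give about 20000 nM in this assay, within a range from 5000 nM to 50000 nM. That estimate corresponds to an expected step of a 1.6-fold lower number from compound 3 to compound 4 (0.20 log units; within the scatter).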

Compound 4, solubility: 32000 nM
Beside the measured number, compound 4's estimate is 1.6-fold (0.20 log units) below it; the range from low to high includes it.
By their numbers in this assay, from the lowest: compound 1; then compounds 2, 3 and 4 (each within the scatter of the next).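

In this assay, a second aromatic ring on this aromatic carbon, with naphthalen-1-yl in place of phenyl, gave no change at the digits printed from compound 3 to compound 4 (within the scatter), and naphthalen-1-yl in place of 4-(tert-butyl)phenyl gave no change at the digits printed from compound 2 to compound 4 (within the scatter), so enlarging the group in a new way, by fusing on a ring rather than adding tert-butyl, also left the number where it was. Among these four compounds, the three with an aromatic ring joined directly at this position stand together, while compound 1, with phenethyl, is the one that goes against them, as naphthalen-1-yl in place of phenethyl repeats the gap with a 7.6-fold higher number from compound 1 to compound 4 (0.88 log units; beyond the scatter). Nothing measured here explains why the numbers fall this way.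

The compounds shown leave open whether the number would stay the same if the aromatic group carried an amine or a carboxylic acid, or if a pyridine ring took the place of the phenyl. They also leave open whether the gap seen with phenethyl would persist with a single methylene link or widen with a longer chain between the two aromatic parts.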